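The source may report more compounds than this note shows. Statements on the series, on what has been measured and on what is new or still open speak of the compounds shown alone.

Compound 1 `CN(C)c1cc2[nH]c(C3CCCCC3)nc2cc1NC(=O)c1ccco1` — in an ADME assay on Vero cells (Chlorocebus sabaeus) for cytotoxicity, read by resazurin assay, with a stated time of 3 days (on this read-out higher numbers stand for weaker inhibition and lower numbers for stronger inhibition), compound 1 gives > 100 ug/mL, a limit of the assay.
Compound 2 `CCCNC(=O)Nc1cc2nc(C3CCCCC3)[nH]c2cc1N(CC)CC` — in this assay compound 2 gives > 100 ug/mL, a limit of the assay.
Compound 3 `CN(C)c1cc2[nH]c(C3CCCCC3)nc2cc1NC(=O)c1ccc(F)cc1` — in this assay compound 3 gives > 100 ug/mL, a limit of the assay.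

Compound 2 therefore stands only at a limit in this assay, and no number is known for it. The change leading to compound 4 `CCN(CC)c1cc2[nH]c(C3CCCCC3)nc2cc1NC(=O)c1ccc(Br)cc1` is 4-bromophenyl in place of propylamino on a carbonyl carbon: propylamino leaves and 4-bromophenyl enters on a carbonyl carbon whose other neighbour is an amide-type nitrogen, so that propylcarbamoyl becomes (4-bromophenyl)carbonyl. Going by the values given here, the one measured step that bears on it is a step that the two limits leave unreadable from compound 1 to compound 3, which also exchanges a group on a carbonyl carbon, but both of its ends sit at a limit and its size cannot be read. Indeed (the limit of > 100 ug/mL in this assay, at which 3 of the 3 values shown sit), so none of the measured steps gives a readable size. Because (the limit of > 100 ug/mL in this assay, at which 3 of the 3 values shown sit), the expected step is a number no higher from compound 2 to compound 4 (the limit leaves the size open), meaning no shift readable beyond the scatter, with a limit the most likely outcome. Compound 4 is therefore estimated at 100 ug/mL, in a range from 40 ug/mL to 250 ug/mL.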

Compound 4, half-maximal inhibitory concentration: > 100 ug/mL
Compound 4: only a limit was reported; the forecaster's own chance of this, stated with the estimate: 75%; the middle value sits exactly at the limit.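

No new step can be read from compound 2 to compound 4, because both stand only at a limit: the limit of > 100 ug/mL in this assay, at which 4 of the 4 values shown sit. The compounds shown leave open what number any of them would give in this assay, and whether exchanging the group on the carbonyl carbon changes it at all.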